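Amide aryl variation: chloro to methyl on the shared core

The source may hold more compounds than are shown below. What is called first, only, known or untested is meant among the compounds shown, and "the series" means these compounds.

Compound 3 `COc1ccc2c(=O)c(/C=C/C(=O)Nc3ccc(Cl)cc3)coc2c1` is one of three amide variants of the shared core. In a functional assay on L02 cells (Homo sapiens) for inhibition, read by MTT assay, with a stated time of 48 h (a lower number here means a stronger inhibitor, a higher number a weaker inhibitor), compound 3 gives > 200000 nM, which is a limit of the assay and not a number. Compound 1 `COc1cccc(NC(=O)/C=C/c2coc3cc(OC)ccc3c2=O)c1` likewise reaches only a limit, > 200000 nM, in this assay. Compound 2 `COc1ccc2c(=O)c(/C=C/C(=O)Nc3ccccc3C)coc2c1` also sits at a limit, > 200000 nM, in this assay. The steps a step that the two limits leave unreadable from compound 1 to compound 2, a step that the two limits leave unreadable from compound 1 to compound 3 and a step that the two limits leave unreadable from compound 2 to compound 3 therefore cannot be sized; the limit of > 200000 nM in this assay, at which 3 of the 3 values shown sit, shows all three values at the same limit. Compound 4 `COc1ccc2c(=O)c(/C=C/C(=O)Nc3ccc(C)cc3)coc2c1` differs from compound 3 by methyl in place of chloro on an aromatic carbon. Among the compounds with values here, no measured step reads, so no direction can be expected from the aryl changes seen so far. Compound 4 is estimated at 300000 nM (range 150000 nM to 1000000 nM). The step that the limit leaves unreadable from compound 3 to compound 4 is expected to remain at the limit.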

Compound 4, half-maximal inhibitory concentration: > 200000 nM
Compound 4 was reported as a limit; the forecaster's own chance of this, stated with the estimate: 90%; the middle value lies beyond the limit too.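

In this assay compound 4 also reaches only a limit, so the steps to compound 4 from compound 1, compound 2 and compound 3 cannot be read. The compounds shown leave open whether any amide aryl change on the shared core alters inhibition in this assay at all.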